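The source may hold more compounds than are shown below. What is called first, only, known or untested is meant among the compounds shown, and "the series" means these compounds.

Measured compounds:
Compound 1 `CCC(C)(C)Cc1c[nH]c(CCc2ccc(-n3cccn3)cc2)n1` — 113 nM
Compound 2 `CCC(C)(C)Cc1c[nH]c(CCc2ccc(-c3cccc(N)n3)cc2)n1` — 119 nM

Compound 2 gives the higher of the two numbers in a functional assay on HEK293 cells for agonist activity at Bombesin receptor subtype-3 (Mus musculus), read by luminescence and calcium flux, with a stated time of 10 min (a lower number here means that less compound is needed, a higher number that more compound is needed for the effect), yet its gap to compound 1, a 1.1-fold higher number from compound 1 to compound 2 (0.02 log units; within the scatter), lies within the scatter. Compound 3 `CCC(C)(C)Cc1c[nH]c(CCc2ccc(N3CCCCC3)cc2)n1` differs from compound 2 in one place: piperidin-1-yl in place of 6-aminopyridin-2-yl on an aromatic carbon. For the measured compounds named here, only the step from compound 1 to compound 2 bears on this change, and it showed a swap of one ring for another at the same place leaving this assay unchanged within the scatter. The present change goes further, exchanging an aromatic ring for a non-aromatic one, so a modest step is expected, a 1.3-fold higher number from compound 2 to compound 3 (0.10 log units; within the scatter), with direction uncertain. Compound 3 is estimated at 150 nM, in the range 50 nM to 450 nM.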

Compound 3, half-maximal effective concentration: 133 nM
Compound 3: middle estimate off by 1.1-fold (0.05 log units), on the high side; the range from low to high includes it.
By their numbers in this assay, from the lowest: compounds 1, 2 and 3 (each within the scatter of the next).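

Replacing either aromatic ring with piperidin-1-yl on this aromatic carbon, para to a large group, gives a 1.1-fold higher number from compound 2 to compound 3 (0.05 log units; within the scatter) and a 1.2-fold higher number from compound 1 to compound 3 (0.07 log units; within the scatter) in this assay. Among these compounds, then, a non-aromatic ring at this place gives a number within the scatter of both aromatic rings, even without the hydrogen-bond donor of 6-aminopyridin-2-yl. No evidence is available to explain this result. From the compounds shown here alone, all three groups are rings, so it remains open whether a carboxylic acid, an open-chain amine or a methyl group here would keep the number in this assay within that scatter.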